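Swapping the aryl group on a triazole nitrogen

The source may report more compounds than this note shows. Statements on the series, on what has been measured and on what is new or still open speak of the compounds shown alone.

Measured compounds in a functional assay on A549 cells (Homo sapiens) for antiproliferative activity, read by MTT assay, with a stated time of 48 h; a lower number here means a stronger inhibitor, a higher number a weaker inhibitor:
- compound 1 `Cc1cccc(-n2nncc2CN2C(=O)C3(C(C#N)=C(N)Oc4c3c3nc5ccccc5nc3c3ccccc43)c3ccccc32)c1` gives 39600 nM
- compound 2 `COc1ccc(-n2nncc2CN2C(=O)C3(C(C#N)=C(N)Oc4c3c3nc5ccccc5nc3c3ccccc43)c3ccccc32)cc1` reaches only the limit of the assay, > 50000 nM
- compound 3 `N#CC1=C(N)Oc2c(c3nc4ccccc4nc3c3ccccc23)C12C(=O)N(Cc1cnnn1-c1cc(Cl)ccc1Cl)c1ccccc12` reaches only the limit of the assay, > 50000 nM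

Going by these compounds, compound 2 stands at the limit of this assay, so its true number is unknown; it shares this position with compound 3, and the limit of > 50000 nM in this assay, at which 2 of the 3 values shown sit, shows that two of the three values shown sit there. Compound 4 `N#CC1=C(N)Oc2c(c3nc4ccccc4nc3c3ccccc23)C12C(=O)N(Cc1cnnn1-c1ccc(Cl)c(Cl)c1)c1ccccc12` differs from compound 2 in one place: 3,4-dichlorophenyl in place of 4-methoxyphenyl on an aromatic nitrogen.

Going by the values given here, two measured steps bear on this change. The step that the two limits leave unreadable from compound 2 to compound 3 is the closest comparison, a dichlorophenyl replacing the methoxyphenyl, but both ends are limits, so its size cannot be read. The step of an at least 1.2-fold higher number from compound 1 to compound 3 (0.10 log units; that floor lies within the scatter) shows that a dichlorophenyl on the same aromatic nitrogen, in place of 3-methylphenyl, gives a number at or beyond the limit. Neither step points to a change beyond the scatter, and nothing here suggests that the 3,4-dichlorophenyl would behave differently from the 2,5-dichlorophenyl of compound 3.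

Compound 4 is therefore expected to remain near the limit of this assay, estimated at 55000 nM, within 25000 nM to 120000 nM. The expected step is a step that the limit leaves unreadable from compound 2 to compound 4, and a report of only a limit is the likely outcome.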

Compound 4, half-maximal inhibitory concentration: > 50000 nM
Compound 4 was reported as a limit; the forecaster's own chance of this, stated with the estimate: 65%; the middle value does not contradict the limit.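

In this assay, compound 4 is a third compound with an aryl group on this aromatic nitrogen to give only a limit, so moving the two chlorines from the 2,5-dichlorophenyl of compound 3 to the 3,4-dichlorophenyl of compound 4 brings no readable change. Going by these compounds alone, the one step that can be read is an at least 1.2-fold higher number from compound 1 to compound 4 (0.10 log units; that floor lies within the scatter), so compound 4 cannot be set apart from compound 1 with its 3-methylphenyl group, and the steps among compound 2, compound 3 and compound 4 cannot be read at all, as both ends of each are limits. The result therefore adds one more aryl group to those that reach the same ceiling: the limit of > 50000 nM in this assay, at which 3 of the 4 values shown sit.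

The compounds shown leave open whether any group at this position can give a number clearly lower than that of compound 1. They also leave open how far past the limit compound 2, compound 3 and compound 4 truly lie. Also open, going by these compounds, is how a phenyl ring carrying an amine or a carboxylic acid, or a plain alkyl chain in place of the aryl ring, would read in this assay.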